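Methylating a Phenol in a Three-Compound Series

The source may hold more compounds than are shown below. What is called first, only, known or untested is meant among the compounds shown, and "the series" means these compounds.

Compound 1 `COc1ccc(/C=C/C2(C)C=CC(=O)O2)c(OC)c1OC`, compound 2 `COc1c(O)ccc(/C=C/C2(C)C=CC(=O)O2)c1OC` and compound 3 `CC1(/C=C/c2ccc(O)cc2)C=CC(=O)O1` were tested in a functional assay on U-251 cells (Homo sapiens) for inhibition, read by sulforhodamine B assay, with a stated time of 48 h; on this read-out higher numbers stand for weaker inhibition of growth and lower numbers for stronger inhibition of growth. Compound 1 gives 87200 nM, compound 2 gives 40700 nM and compound 3 gives 107000 nM in this assay. Compound 2 and compound 1 differ in one place, (methyl in place of hydrogen on an oxygen on an aromatic ring), and that step a 2.1-fold higher number from compound 2 to compound 1 (0.33 log units; beyond the scatter). How the core of compound 2 differs from that of compound 3 is not broken down here.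

Compound 4 `COc1ccc(/C=C/C2(C)C=CC(=O)O2)cc1` has not yet been measured. It carries the same change relative to compound 3, (methyl in place of hydrogen on an oxygen on an aromatic ring), at a place described in identical terms. Because the earlier step of a 2.1-fold higher number from compound 2 to compound 1 (0.33 log units; beyond the scatter), a step of similar size is expected here, so compound 4 is expected to give a 1.9-fold higher number from compound 3 to compound 4 (0.27 log units; within the scatter). This rests on a single earlier instance, so the estimate is uncertain; compound 4 is expected to give 200000 nM, within 100000 nM to 400000 nM.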

Compound 4, concentration for total growth inhibition: 127000 nM
The estimate for compound 4 lay 1.6-fold (0.20 log units) above the measured number; the range from low to high includes it.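

In this assay, replacing the hydroxy group with a methoxy group gives a 1.2-fold higher number from compound 3 to compound 4 (0.07 log units; within the scatter). Set beside the earlier step, the two cores cannot be told apart: the same change on two cores in this assay, a 2.1-fold higher number (0.33 log units; beyond the scatter) from compound 2 to compound 1 and a 1.2-fold higher number (0.07 log units; within the scatter) from compound 3 to compound 4, 1.8-fold (0.26 log units) apart, within the scatter of two such steps. The change therefore carries from one core to the other with no detectable difference in size, but two steps, one of them within the scatter, cannot show that it would have the same size on any other core, and they do not explain its size.

The compounds shown carry only hydrogen or methyl on this oxygen. Going by these compounds, what a longer chain such as ethyl would do there, or an amine in place of the hydroxy group, remains open.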